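This account rests on a few compounds, and the source may have more. Where it says the series, first, only, none or still open, it means among the compounds named here.

Measured so far: compound 1 `COc1cc2nc(N3CCC(C(=O)NC4CCCC4)CC3)nc(N)c2cc1OC` with 0.63 nM; compound 2 `CCN(CC)C(=O)C1CCN(c2nc(N)c3cc(OC)c(OC)cc3n2)CC1` with 1.11 nM; compound 3 `COc1cc2nc(N3CCC(C(=O)NCc4ccccc4)CC3)nc(N)c2cc1OC` with 0.22 nM.

All three share a core and differ only in the amide substituent on the piperidine-type ring. In an assay on isolated protein for displacement of a labelled ligand from Adrenergic receptor alpha-1 (Rattus norvegicus) (on this read-out higher numbers stand for weaker inhibition and lower numbers for stronger inhibition), compound 3 gives the lowest number of the three, separated from the others by a 2.9-fold lower number from compound 1 to compound 3 (0.46 log units; beyond the scatter) and by a 5.0-fold lower number from compound 2 to compound 3 (0.70 log units; beyond the scatter), both beyond the scatter. Compound 4 `CCCCNC(=O)CC1CCN(c2nc(N)c3cc(OC)c(OC)cc3n2)CC1` carries (butylcarbamoyl)methyl in place of benzylcarbamoyl on a saturated ring carbon. The two measured steps leading into compound 3 both bear on this change: exchanging a non-aromatic substituent for the benzyl group lowered the number in each case, so removing the aromatic ring again is expected to raise it. An estimated step of a 3.2-fold higher number from compound 3 to compound 4 (0.50 log units; beyond the scatter) is expected, placing compound 4 at 0.7 nM with a range from 0.25 nM to 2.5 nM.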

Compound 4, inhibition constant: 1.4 nM
Estimate against measurement, compound 4: 2.0-fold (0.30 log units) below; measured number inside the range.
By their numbers in this assay, from the lowest: compound 3; then compounds 1, 2 and 4 (each within the scatter of the next, the first and the last beyond it).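

In this assay, replacing benzylcarbamoyl with the ring-free (butylcarbamoyl)methyl group gives a 6.4-fold higher number from compound 3 to compound 4 (0.80 log units; beyond the scatter), a larger step than the one from the cyclopentyl amide, a 2.2-fold higher number from compound 1 to compound 4 (0.35 log units; beyond the scatter), while the step from the diethyl amide is only a 1.3-fold higher number from compound 2 to compound 4 (0.10 log units; within the scatter). Within the data shown here, compound 3, the only one with an aromatic ring, thus stays apart from a straight-chain amide as well as from the cyclic and branched ones. No measurement available here accounts for this.

The step changes the amide substituent and adds the methyl link in one move, so their shares remain unseparated. A plain butylcarbamoyl group or a (benzylcarbamoyl)methyl group would separate them.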